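This account rests on a few compounds, and the source may have more. Where it says the series, first, only, none or still open, it means among the compounds named here.

Measured compounds:
Compound 1: `COc1ccc(C(Nc2cc(C)ccn2)c2ccc3cccnc3c2O)cc1O` — 150 nM
Compound 2: `Cc1cc(C)c(C(Nc2ccccn2)c2ccc3cccnc3c2O)c(C)c1` — 190 nM

Of the compounds shown here, two have so far been measured in an assay for inhibition of protein disulfide-isomerase (Homo sapiens), with a stated time of 1 h; on this read-out lower numbers stand for stronger inhibition and higher numbers for weaker inhibition. Compound 1 `COc1ccc(C(Nc2cc(C)ccn2)c2ccc3cccnc3c2O)cc1O` gives 150 nM, and compound 2 `Cc1cc(C)c(C(Nc2ccccn2)c2ccc3cccnc3c2O)c(C)c1` gives 190 nM in this assay. Compound 1 has the lower of the two numbers, but its gap to compound 2 lies within the scatter, so the two cannot be told apart on these data. Going by the values given here, no pair of measured compounds differing in a single place is available, so no measured step guides the next comparison.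

Compound 3 `Cc1ccnc(NC(c2ccc3cccnc3c2O)c2c(Cl)cccc2Cl)c1` has not yet been measured. It differs from compound 1 in one place: 2,6-dichlorophenyl in place of 3-hydroxy-4-methoxyphenyl on a saturated chain carbon bound to an aromatic carbon and a nitrogen on an aromatic ring. The measured set offers only an indirect hint: compound 1 and compound 2 carry quite different rings on that carbon and still give numbers within the scatter of each other. The step from compound 1 to compound 3 is therefore expected to be a 1.7-fold higher number from compound 1 to compound 3 (0.22 log units; within the scatter), a change not clearly beyond the scatter. Compound 3 is estimated at 250 nM, with a range from 80 nM to 800 nM.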

Compound 3, half-maximal inhibitory concentration: > 40000 nM
Compound 3 gave a limit, no number; the forecaster's own chance of this, stated with the estimate: 5%; middle value at least 160-fold (2.20 log units) away from the limit.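

At the position on a saturated chain carbon bound to an aromatic carbon and a nitrogen on an aromatic ring, this assay now has its first measured single change: 2,6-dichlorophenyl in place of 3-hydroxy-4-methoxyphenyl gives an at least 260-fold higher number from compound 1 to compound 3 (2.42 log units; beyond the scatter). Going by these compounds alone, this large step shows that the ring carried on this carbon can decide the read-out, which no earlier pair of compounds could show. The value of compound 3 is a limit of the assay and not a number, so the step sets only a lower bound on the change and its full size cannot be read: the limit of > 40000 nM in this assay, at which 1 of the 3 values shown sits.

The compounds shown leave open which part of the exchange carries the step, whether the departure of the hydroxy and methoxy groups or the arrival of the two chlorines. Also open, going by these compounds, is how an unsubstituted phenyl ring, or a phenyl ring bearing a single chlorine, an amine or a carboxylic acid, would read on this carbon in this assay.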